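The source may hold more compounds than are shown below. What is called first, only, known or untested is meant among the compounds shown, and "the series" means these compounds.

Two sulfonamides sharing the same bis(trifluoromethyl)phenyl core have been measured. Compound 1 `O=S(=O)(NCCNCc1ccc(-c2ccccc2)cc1)c1cc(C(F)(F)F)cc(C(F)(F)F)c1` gives 2700 nM in a functional assay on HT-29 cells (Homo sapiens) for inhibition, read by MTT assay, with a stated time of 72 h; a lower number here means a stronger inhibitor of growth, a higher number a weaker inhibitor of growth. Compound 2 `O=S(=O)(NCCCCNCc1ccc(Br)cc1)c1cc(C(F)(F)F)cc(C(F)(F)F)c1` gives 1600 nM in this assay, the lower of the two numbers, though compound 1 lies within the scatter of it. Compound 3 `CN(CCCNS(=O)(=O)c1cc(C(F)(F)F)cc(C(F)(F)F)c1)Cc1ccccc1` has not yet been measured; it differs from compound 2 by benzyl(methyl)amino in place of ((4-bromobenzyl)amino)methyl on a saturated chain carbon, three bonds along the chain from a sulfonamide nitrogen. Among the measured compounds shown here, no measured step covers this change, so only a weak expectation is possible: a small shift toward a higher number, possibly none beyond the scatter, is expected, a 2.0-fold higher number from compound 2 to compound 3 (0.30 log units; within the scatter). Compound 3 is estimated at 3200 nM, within 1200 nM to 9000 nM.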

Compound 3, concentration for 50% growth inhibition: > 50000 nM
Compound 3 ended at the assay's limit; the forecaster's own chance of this, stated with the estimate: 10%; middle value at least 15-fold (1.19 log units) away from the limit.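

Replacing ((4-bromobenzyl)amino)methyl with benzyl(methyl)amino on this saturated chain carbon gives an at least 31-fold higher number from compound 2 to compound 3 (1.49 log units; beyond the scatter) in this assay, the first step measured in this series. It shows that growth inhibition depends strongly on what sits at this place. Compound 3 gives > 50000 nM, which is a limit of the assay: the limit of > 50000 nM in this assay, at which 1 of the 3 values shown sits.

The step removes the bromine and a hydrogen-bond donor in one change, so the compounds shown do not separate the two. On these data alone, whether a chlorine or a methoxy group in place of the bromine would retain growth inhibition remains open.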